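The compounds below may be only part of what the source reports. "The series", "measured", "known", "first", "only" and "open" are said of these compounds alone.

Measured so far in an ADME assay on HFF cells (Homo sapiens) for cytotoxicity; on this read-out higher numbers stand for lower toxicity in this test and lower numbers for higher toxicity in this test:
- compound 1 `Nc1ncc(F)c2c1ncn2[C@@H]1C[C@H](CO)[C@@H](O)[C@H]1O`: > 178000 nM, a limit
- compound 2 `Nc1ncc(F)c2c1ncn2[C@@H]1C[C@H](CCO)[C@@H](O)[C@H]1O`: > 264000 nM, a limit

Compound 2 stands at > 264000 nM, which is a limit of the assay and not a number. The other value, > 178000 nM for compound 1, is also a limit, so neither compound has a numerical read-out in this assay.

Compound 3 `Nc1ncc(F)c2c1ncn2[C@@H]1C[C@H](O)[C@@H](O)[C@H]1O` carries hydroxy in place of 2-hydroxyethyl on a saturated ring carbon.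

Within the data shown here, the one measured step that bears on this change is a shorter change at the same carbon, a step that the two limits leave unreadable from compound 1 to compound 2. It gives no size and no direction. No step beyond the usual scatter is therefore expected, and the expected step is an at least 1.2-fold lower number from compound 2 to compound 3 (0.07 log units; that floor lies within the scatter). A further limit is the likeliest outcome for this compound. Compound 3 is estimated at 220000 nM, with an expected range of 80000 nM to 450000 nM.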

Compound 3, half-maximal cytotoxic concentration: > 300000 nM
Compound 3: no number, only a limit; the forecaster's own chance of this, stated with the estimate: 75%; at least 1.3-fold (0.13 log units) between middle value and limit.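

In this assay compound 3 gives > 300000 nM, a limit and not a number. Among these compounds, compound 1 and compound 2 also stand at limits, so no step among the three can be read. As far as these compounds go, whether the hydroxy, hydroxymethyl and 2-hydroxyethyl groups differ on this read-out, and by how much, stays open.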